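The source may report more compounds than this note shows. Statements on the series, on what has been measured and on what is new or still open speak of the compounds shown alone.

Working notes on the series. Going by the values given here, in an assay on cells for inhibition of HSP60/HSP10 (Homo sapiens), with a stated time of 60 min (a higher number here means a weaker inhibitor, a lower number a stronger inhibitor), compound 3 `O=S(=O)(Nc1ccc(-c2nc3cc(NS(=O)(=O)c4cccs4)ccc3o2)cc1)c1cccs1` gives 40000 nM, the only numerical value in the set. Compound 1 `Cc1ccc(S(=O)(=O)Nc2ccc3oc(-c4ccccc4)nc3c2)cc1` returns the assay limit, > 100000 nM. Compound 2 `O=S(=O)(Nc1ccc(-c2nc3ccccc3o2)cc1)c1ccccc1Cl` likewise stops at the limit, > 100000 nM. Given (the limit of > 100000 nM in this assay, at which 2 of the 3 values shown sit), compound 3 is the sole member with a measurable number. Compound 4 `O=S(=O)(Nc1ccc(-c2nc3ccccc3o2)cc1)c1cccs1` differs from compound 3 by hydrogen in place of ((thiophen-2-yl)sulfonyl)amino on an aromatic carbon, on a six-membered carbon ring of the fused system, meta and para to the fused ring. Among the compounds with values here, no measured pair isolates this change; compound 1 and compound 2, each carrying a single sulfonylamino group, sit at the limit in this assay. A loss of potency beyond the scatter is therefore expected a 2.5-fold higher number from compound 3 to compound 4 (0.40 log units; beyond the scatter). Compound 4 is estimated at 100000 nM, within 40000 nM to 300000 nM, likely reported only as a limit.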

Compound 4, half-maximal inhibitory concentration: 63000 nM
For compound 4 the middle estimate is 1.6-fold (0.20 log units) above the measured one, and the stated range covers the measured number.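

Hydrogen in place of ((thiophen-2-yl)sulfonyl)amino on this aromatic carbon gives a 1.6-fold higher number from compound 3 to compound 4 (0.20 log units; within the scatter) in this assay and shows that a measurable value does not depend on this group. Thiophen-2-yl in place of 2-chlorophenyl on the sulfonyl sulfur gives an at least 1.5-fold lower number from compound 2 to compound 4 (0.20 log units; that floor lies within the scatter) as a floor that does not separate the two groups. Compound 2 gives > 100000 nM as a limit of the assay. Open, from the compounds shown here alone, is whether an amine or a carboxylic acid on this aromatic carbon would move the value beyond the scatter. Also open, going by these compounds, is what methyl on the sulfonyl sulfur would give.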